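The source may hold more compounds than are shown below. What is called first, only, known or untested is meant among the compounds shown, and "the series" means these compounds.

Compound 1 `CCOC(=O)NS(=O)(=O)Oc1c(C(C)C)cccc1C(C)C`, compound 2 `CC(C)c1cccc(C(C)C)c1OS(=O)(=O)NC(=O)Oc1ccc(F)cc1`.

In an assay on liver for inhibition of sterol O-acyltransferase 1 (Rattus norvegicus), using microsomes (a higher number here means a weaker inhibitor, a lower number a stronger inhibitor), compound 1 gives > 50000 nM; > 50000 nM (2 entries), which is a limit of the assay rather than a number. In this assay compound 2 gives > 50000 nM, again only a limit; for compound 2 no single number is known, only this boundary (the limit of > 50000 nM in this assay, at which 1 of the 2 values shown sits). Compound 3 `CC(C)c1ccccc1OC(=O)NS(=O)(=O)Oc1c(C(C)C)cccc1C(C)C` differs from compound 2 by 2-isopropylphenyl in place of 4-fluorophenyl on an oxygen next to a carbonyl group. Since neither measured compound yielded a number, no step size can be read from the data, and no shift beyond the usual scatter is expected from compound 2 to compound 3 a number no higher from compound 2 to compound 3 (the limit leaves the size open). Compound 3 is therefore expected to give 50000 nM, within 15000 nM to 150000 nM, most probably again as a limit only.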

Compound 3, half-maximal inhibitory concentration: > 50000 nM
Compound 3: no number, only a limit; the forecaster's own chance of this, stated with the estimate: 80%; the middle value sits exactly at the limit.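

No step can be read from compound 2 to compound 3, because both values are only limits: the limit of > 50000 nM in this assay, at which 2 of the 3 values shown sit. The compounds shown leave open how strong an inhibitor each one is, and whether 2-isopropylphenyl and 4-fluorophenyl differ in effect at all.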